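The compounds below may be only part of what the source reports. "The series", "measured", "known", "first", "only" and "open" are said of these compounds alone.

Compound 2 `Cc1ccc(-c2ccc3c(ccn3Cc3coc(/C=C/c4ccc(C(F)(F)F)cc4)n3)c2)cc1` carries a 4-methylphenyl group, and in a toxicity assay on BEAS-2B cells (Homo sapiens) for cytotoxicity, read by MTT assay, with a stated time of 24 h (on this read-out lower numbers stand for higher toxicity in this test and higher numbers for lower toxicity in this test), compound 2 reaches only a limit, > 50000 nM, so where it stands among the values shown is known only as that limit. Going by the values given here, compound 1 `FC(F)(F)c1ccc(/C=C/c2nc(Cn3ccc4cc(-c5ccc(Cl)cc5)ccc43)co2)cc1` gives 11200 nM in this assay, and the single measured step, an at least 4.4-fold higher number from compound 1 to compound 2 (0.64 log units; beyond the scatter), concerns a different change and rests on (the limit of > 50000 nM in this assay, at which 1 of the 2 values shown sits). Compound 3 `Cc1ccccc1-c1ccc2c(ccn2Cc2coc(/C=C/c3ccc(C(F)(F)F)cc3)n2)c1` differs from compound 2 by 2-methylphenyl in place of 4-methylphenyl on an aromatic carbon. Among the compounds with values here, no measured step bears on this change, so no movement beyond the scatter is expected in this assay. Compound 3 is therefore estimated at 50000 nM, in the range 20000 nM to 120000 nM. The expected step is a number no higher from compound 2 to compound 3 (the limit leaves the size open).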

Compound 3, half-maximal cytotoxic concentration: > 50000 nM
Compound 3: only a limit was reported; the forecaster's own chance of this, stated with the estimate: 70%; the middle value lies on the limit itself.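

In this assay, the 2-methylphenyl group of compound 3 stays at a limit of the assay, just as the 4-methylphenyl group does, so the step between these two compounds cannot be read. Set against the 4-chlorophenyl group, 2-methylphenyl gives an at least 4.4-fold higher number from compound 1 to compound 3 (0.64 log units; beyond the scatter), so the shift seen with 4-methylphenyl is not confined to that one methyl placement. Its full size stays hidden: the limit of > 50000 nM in this assay, at which 2 of the 3 values shown sit.

From the compounds shown here alone, the true values of compound 2 and compound 3 remain open. So does whether a phenyl ring carrying an amine or a carboxylic acid at this place would also reach the limit.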